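The source may report more compounds than this note shows. Statements on the series, on what has been measured and on what is new or still open speak of the compounds shown alone.

Measured so far in a functional assay on MT4 cells (Homo sapiens) for cytotoxicity; a lower number here means that less compound is tolerated, a higher number that more compound is tolerated:
Compound 1 `COc1ccc(-c2c(C)nc(S)n2Nc2cccc(Cl)c2)cc1` gives 38700 nM.
Compound 2 `Cc1nc(S)n(Nc2cccc(Cl)c2)c1-c1cccc(Cl)c1` gives 31000 nM.

Both compounds share one core and differ only in the ring that hangs off it. Compound 2 sits at one end of the two numbers, with compound 1 close to it and within the usual scatter of this assay, so the two compounds cannot be told apart on the amount of compound the cells tolerate.

Compound 3 `Cc1nc(S)n(Nc2cccc(Cl)c2)c1-c1ccccc1` has not yet been measured. It comes from compound 2 by a small change: hydrogen in place of chloro on an aromatic carbon. Nothing else in the structure moves.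

For the measured compounds named here, no measured pair here shows what this particular change does, so the expectation rests on how close the two measured compounds lie to each other. The step from compound 2 to compound 3 in this assay is expected to be small, most likely none beyond the scatter, with a slight lean toward a higher number: a 1.3-fold higher number from compound 2 to compound 3 (0.11 log units; within the scatter). Compound 3 is therefore estimated to give 40000 nM, with a range from 20000 nM to 90000 nM.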

Compound 3, half-maximal cytotoxic concentration: 66700 nM
Compound 3: the middle estimate sits 1.7-fold (0.22 log units) below what was measured; low and high end bracket the measured number.
By their numbers in this assay, from the lowest: compounds 2, 1 and 3 (each within the scatter of the next, the first and the last beyond it).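

In this assay the change from 3-chlorophenyl to phenyl gives a 2.2-fold higher number from compound 2 to compound 3 (0.33 log units; beyond the scatter) and so the cells tolerate more of the compound once this chloro is gone, although the step is modest and only just clears the usual scatter. The replacement of methoxy by hydrogen on the same ring gives a 1.7-fold higher number from compound 1 to compound 3 (0.24 log units; within the scatter) and stays within the scatter, so this second change cannot be told apart from no change at all. Together, the two steps offer a first sign that the group on this ring can shift tolerance a little, but no measurement here explains the size of either step.

Still open, as far as these compounds go, is what other groups would do on this aromatic carbon: fluoro, an amine or a carboxylic acid could each raise the number, lower it or leave it unchanged. From the compounds shown here alone, all three compounds also carry the same 3-chlorophenyl group on the other side of the shared core, so the effect of changing that group remains unknown.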